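The compounds below may be only part of what the source reports. "The series", "measured", "known", "first", "only" and "open" are said of these compounds alone.

In an ADME assay on MDA-MB-231 cells (Homo sapiens) for cytotoxicity, read by MTT assay, with a stated time of 72 h (a lower number here means a stronger inhibitor, a higher number a weaker inhibitor), compound 2 `COC(=O)[C@@H](C)NC(=O)[C@@H](C)NC(=O)Cn1cc(CN(Cc2ccccn2)Cc2ccccn2)nn1` gives 152000 nM. Its mirror image, compound 3 `COC(=O)[C@H](C)NC(=O)[C@H](C)NC(=O)Cn1cc(CN(Cc2ccccn2)Cc2ccccn2)nn1`, gives 157000 nM, so these two stand level. Compound 1 `COC(=O)[C@@H](C)NC(=O)[C@@H](C)NC(=O)CN(C)CCN(Cc1ccccn1)Cc1ccccn1` gives 4500 nM, a lower number than either, which makes compound 2 a weak inhibitor among the three measured compounds. However, compound 1 differs from compound 2 in more than the part of the structure considered here, so it offers no direct guide.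

The unmeasured compound is compound 4 `COC(=O)CNC(=O)CNC(=O)Cn1cc(CN(Cc2ccccn2)Cc2ccccn2)nn1`. The structural change is (((methoxycarbonyl)methyl)carbamoyl)methyl in place of 1-((1-(methoxycarbonyl)ethyl)carbamoyl)ethyl on an amide-type nitrogen, and the defined stereocentres disappear with it. Among the measured compounds shown here, the one measured step that bears on this is a 1.0-fold higher number from compound 2 to compound 3 (0.01 log units; within the scatter), and it reflects (the fact that compounds 2 and 3 differ only in the configuration as drawn). That step lies within the scatter, so inverting these stereocentres left the number unchanged. It does not test their removal, so it is only a loose guide, and the range must stay wide. No step beyond the scatter is therefore expected in this assay. The expected size of the change is a 1.0-fold lower number from compound 2 to compound 4 (0.01 log units; within the scatter). Compound 4 is estimated at 150000 nM, with an expected range from 70000 nM to 300000 nM.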

Compound 4, half-maximal inhibitory concentration: 168000 nM
Compound 4: middle estimate off by 1.1-fold (0.05 log units), on the low side, within the range that was stated.
By their numbers in this assay, from the lowest: compound 1; then compounds 2, 3 and 4 (each within the scatter of the next).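

Removing the stereocentres altogether, not merely inverting them, leaves no readable change in this assay: the replacement gives a 1.1-fold higher number from compound 2 to compound 4 (0.04 log units; within the scatter) and a 1.1-fold higher number from compound 3 to compound 4 (0.03 log units; within the scatter). The group on this amide-type nitrogen can therefore go from 11 heavy atoms to 9 and lose both defined stereocentres while the number stays level. The mirror-image pair could not show this, since it tested only inversion and not removal: the fact that compounds 2 and 3 differ only in the configuration as drawn. Compounds 2, 3 and 4 thus stand level, so neither the configuration nor the presence of these stereocentres separates them in this assay.

As far as these compounds go, whether a bulkier side chain on the same backbone, such as isopropyl or benzyl, would also leave the number level remains open, as does the outcome of a carboxylic acid in place of the methyl ester. Compound 1, at 4500 nM, differs from the other compounds in more than one place, so the compounds shown do not tell which part of its structure goes with its value.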